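Methyl for Chloro on Two Related Cores

A few compounds are considered here, and "the series" means these few. Any claim that something is new, unique, unknown or untested is made for them only; others in the source may bear on it.

Of the compounds shown here, three have been measured in a functional assay on DU-145 cells (Homo sapiens) for cytotoxicity, read by sulforhodamine B assay (on this read-out higher numbers stand for weaker inhibition of growth and lower numbers for stronger inhibition of growth), and a fourth awaits its number. Compound 1 `COc1ccc2c(c1)CCN2c1nc(Cl)nc2ccccc12` gives 165 nM in this assay. Compound 2 `COc1ccc2c(c1)CCN2c1nc(C)nc2ccccc12` carries a methyl in place of chloro on an aromatic carbon and gives 243 nM in this assay; the counted difference is methyl in place of chloro on an aromatic carbon, and the step of a 1.5-fold higher number from compound 1 to compound 2 (0.17 log units; within the scatter) is small. Compound 3 `COc1ccc2c(c1)CCCN(c1nc(Cl)nc3ccccc13)C2` is built on a different core; how its core differs from that of compound 1 is not broken down here. In this assay compound 3 gives 6810 nM, the highest number among the three, well apart from compound 1 and compound 2.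

Compound 4 `COc1ccc2c(c1)CCCN(c1nc(C)nc3ccccc13)C2` stands to compound 3 as compound 2 stands to compound 1: the change is methyl in place of chloro on an aromatic carbon, and its place is described in the same words as the earlier one, so it is the same change on a different core. That change was made only once where a measurement exists, and there it moved the number little. Resting on compound 3 at 6810 nM and on the earlier step of a 1.5-fold higher number from compound 1 to compound 2 (0.17 log units; within the scatter), the step of a 1.4-fold higher number from compound 3 to compound 4 (0.14 log units; within the scatter) is expected to be small, in the same direction or within the scatter. Compound 4 is therefore estimated at 9500 nM in this assay, with a likely range from 4000 nM to 25000 nM, pending the measurement itself.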

Compound 4, concentration for 50% growth inhibition: 14600 nM
For compound 4 the middle estimate is 1.5-fold (0.19 log units) below the measured one; low and high end bracket the measured number.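

In this assay, methyl in place of chloro on an aromatic carbon gives a 2.1-fold higher number from compound 3 to compound 4 (0.33 log units; beyond the scatter), a modest step that lies just beyond the scatter, whereas the same change on the core of compound 1 stayed within it. Even so, the two steps run in the same direction and cannot be told apart, so in these two pairs the change carried over from one core to the other with much the same size: the same change on two cores in this assay, a 1.5-fold higher number (0.17 log units; within the scatter) from compound 1 to compound 2 and a 2.1-fold higher number (0.33 log units; beyond the scatter) from compound 3 to compound 4, 1.5-fold (0.16 log units) apart, within the scatter of two such steps. This rests on just two pairs, so it does not show that the step would keep its size or direction on any further core, and it gives no reason for the size of the step on either core.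

The compounds shown hold only chloro and methyl on the carbon between the two ring nitrogen atoms, which leaves open how an amine or a longer chain such as propyl would fare there on either core. From the compounds shown here alone, the methoxy group is also the same in all four compounds, so it remains open whether a hydroxyl in its place would change the number in this assay, and whether it would do so equally on both cores.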